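One Chloro Exchanged for Trifluoromethyl: Compound 1 to Compound 4

The compounds below may be only part of what the source reports. "The series", "measured", "known", "first", "only" and "open" are said of these compounds alone.

Of the compounds shown here, three built on a shared core have been measured in a functional assay on DU-145 cells (Homo sapiens) for inhibition, read by sulforhodamine B assay, with a stated time of 48 h; on this read-out higher numbers stand for weaker inhibition of growth and lower numbers for stronger inhibition of growth. Compound 1 `O=C(Nc1cccc(-n2cc(-c3ccncc3)c(-c3ccc(Cl)c(O)c3)n2)c1)Nc1ccc(Cl)c(Cl)c1` gives 1500 nM in this assay. Compound 2 `O=C(Nc1cccc(-n2cc(-c3ccncc3)c(-c3ccc(Cl)c(O)c3)n2)c1)Nc1cc(C(F)(F)F)cc(C(F)(F)F)c1` gives 1250 nM, and compound 3 `COc1cc(-c2nn(-c3cccc(NC(=O)Nc4cccc(C(F)(F)F)c4)c3)cc2-c2ccncc2)ccc1Cl` gives 1670 nM. Compound 1 stands second highest of the three numbers; its nearest neighbour is compound 3 and its furthest is compound 2, and both of those gaps lie within the scatter of repeated measurements, so the three compounds cannot be ordered against one another.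

Compound 4 `O=C(Nc1cccc(-n2cc(-c3ccncc3)c(-c3ccc(Cl)c(O)c3)n2)c1)Nc1ccc(Cl)c(C(F)(F)F)c1` has not yet been measured. It differs from compound 1 in a single place: trifluoromethyl in place of chloro on an aromatic carbon. Within the data shown here, no measured pair differs in exactly this way, so there is no measured step to lean on. What the data do show is that compound 2, which carries trifluoromethyl groups, gives a number within the scatter of compound 1 and compound 3. Compound 4 is therefore expected to give about 1350 nM, with a range from 600 nM to 3000 nM. The step of a 1.1-fold lower number from compound 1 to compound 4 (0.05 log units; within the scatter) is expected to be none beyond the scatter.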

Compound 4, concentration for 50% growth inhibition: 1130 nM
Beside the measured number, compound 4's estimate is 1.2-fold (0.08 log units) above it, and the stated range covers the measured number.
By their numbers in this assay, from the lowest: compounds 4, 2, 1 and 3 (each within the scatter of the next).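

In this assay, the exchange of chloro for trifluoromethyl on this aromatic carbon, ortho to a chloro group and meta to a large group, gives a 1.3-fold lower number from compound 1 to compound 4 (0.12 log units; within the scatter) and so provides a direct measured step at this position. The 3,4-dichlorophenyl and 4-chloro-3-(trifluoromethyl)phenyl groups therefore cannot be told apart here, even though a group of 4 heavy atoms enters where a group of 1 heavy atom leaves. Nothing in the data accounts for this result.

The compounds shown leave open whether a group of another kind on this carbon, such as an amine or a carboxylic acid, would move the number beyond the scatter. They also leave open whether the chloro group that remains in compound 4 could be exchanged for either of these with as little effect.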